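The source may report more compounds than this note shows. Statements on the series, on what has been measured and on what is new or still open speak of the compounds shown alone.

Measured in a functional assay on DU-145 cells (Homo sapiens) for inhibition, read by CCK-8 assay, with a stated time of 72 h; a lower number here means a stronger inhibitor, a higher number a weaker inhibitor:
- Compound 1 `O=C(/C=C/c1cccnc1)NCCCc1ccc(S(=O)(=O)Nc2ccccc2)cc1`: > 10000 nM (a limit of the assay, not a number)
- Compound 2 `O=C(/C=C/c1cccnc1)NCCCCCc1ccc(S(=O)(=O)Nc2ccccc2)cc1`: 581 nM
- Compound 3 `Cc1ccc(C)c(NS(=O)(=O)c2cccc(CCCCCCNC(=O)/C=C/c3cccnc3)c2)c1`: 7.48 nM

Of these three entries, only compound 2 and compound 3 have actual numbers. The entry for compound 1 is a limit and gives no number to compare. Compound 3, at 7.48 nM, has the lower of the two numbers, and the gap to compound 2, at 581 nM, lies well beyond the scatter. These measured compounds differ from one another in more than one place, so none of them isolates the effect of a single change.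

The next compound, compound 4 `O=C(/C=C/c1cccnc1)NCCCCCCc1cccc(S(=O)(=O)Nc2ccc(F)c(Cl)c2)c1`, departs from compound 3 at one place only: 3-chloro-4-fluorophenyl in place of 2,5-dimethylphenyl on a sulfonamide nitrogen. It has 3-chloro-4-fluorophenyl in place of 2,5-dimethylphenyl on a sulfonamide nitrogen. Going by the values given here, no measured pair shows what a swap at this nitrogen does in this assay, so the direction of any change cannot be read from the data. The expectation is therefore no shift beyond the scatter, with wide uncertainty on either side. The estimated change is a 1.6-fold higher number from compound 3 to compound 4 (0.21 log units; within the scatter). For compound 4 the expected value is 12 nM, with an estimated range of 2 nM to 80 nM.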

Compound 4, half-maximal inhibitory concentration: 150 nM
Compound 4: the middle estimate sits 13-fold (1.10 log units) below what was measured; measured number outside the range, above it.
By their numbers in this assay, from the lowest: compound 3; then compound 4; then compound 2. At a limit, above all of these: compound 1.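

In this assay, going by these compounds alone, the group on the sulfonamide nitrogen is the first place where a single change can be read, and the swap of 2,5-dimethylphenyl for 3-chloro-4-fluorophenyl gives a 20-fold higher number from compound 3 to compound 4 (1.30 log units; beyond the scatter). The number is therefore sensitive to what this ring carries, even though the group that leaves and the group that enters have the same number of heavy atoms, each is one six-membered aromatic ring of carbon only, and neither adds a hydrogen-bond donor or acceptor. Nothing measured here bears on the reason for this step.

Within the data shown here, with only this one pair, the step cannot be divided between losing the two methyl groups, gaining the chlorine and the fluorine, and the change in where the ring carries its substituents. The compounds shown also leave open how this nitrogen would respond to a phenyl ring with a single methyl, a single chlorine or a single fluorine, or to a pyridine ring in its place, any of which would help to show which part of the change drives the step.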